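A Hydroxyl in Place of a Methyl Ether

The compounds below may be only part of what the source reports. "The series", "measured", "known", "first", "only" and "open" are said of these compounds alone.

Compound 1 `O=c1ncccn1SCCc1ccc(Nc2ncc(Cc3c(F)cccc3F)o2)cc1` gives only a limit, > 100000 nM, in an ADME assay on MT2 cells (Homo sapiens) for cytotoxicity, read by MTT assay; on this read-out lower numbers stand for higher toxicity in this test and higher numbers for lower toxicity in this test.
Compound 2 `Fc1cccc(F)c1Cc1cnc(Nc2ccc(Oc3cccnc3)cc2)o1` gives 22000 nM in this assay.
Compound 3 `COCc1ccc(Nc2ncc(Cc3c(F)cccc3F)o2)cc1` gives 32000 nM in this assay.

Compound 3 holds the higher of the two numbers, with compound 2 nearest: a 1.5-fold higher number from compound 2 to compound 3 (0.16 log units; within the scatter). Compound 4 `OCCc1ccc(Nc2ncc(Cc3c(F)cccc3F)o2)cc1` is not yet measured; it differs from compound 3 by hydroxymethyl in place of methoxy on a saturated chain carbon bound to an aromatic carbon. For the measured compounds named here, no measured step touches this same exchange. an at least 3.1-fold lower number from compound 1 to compound 3 (0.49 log units; beyond the scatter) swaps a far larger group at the same chain carbon, and a 1.5-fold higher number from compound 2 to compound 3 (0.16 log units; within the scatter) concerns the aromatic carbon, so neither speaks for a hydroxyl against a methyl ether. No step beyond the scatter is therefore expected in this assay. Compound 4 is expected to give 35000 nM, within 15000 nM to 100000 nM. This expectation for compound 4 means a 1.1-fold higher number from compound 3 to compound 4 (0.04 log units; within the scatter).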

Compound 4, half-maximal cytotoxic concentration: 35000 nM
Beside the measured number, compound 4's estimate shows no gap at the digits printed; the measured number falls inside the stated range.
By their numbers in this assay, from the lowest: compounds 2, 3 and 4 (each within the scatter of the next). At a limit, above all of these: compound 1.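

Exchanging methoxy for hydroxymethyl on a saturated chain carbon bound to an aromatic carbon adds a hydrogen-bond donor without shifting the number in this assay beyond the scatter (a 1.1-fold higher number from compound 3 to compound 4 (0.04 log units; within the scatter)). For the compounds shown here, the 2-hydroxyethyl group in place of (pyridin-3-yl)oxy also stays within the scatter (a 1.6-fold higher number from compound 2 to compound 4 (0.20 log units; within the scatter)), while replacing the far larger group gives the only step beyond it (an at least 2.8-fold lower number from compound 1 to compound 4 (0.45 log units; beyond the scatter)). That step rests on a limit for compound 1: the limit of > 100000 nM in this assay, at which 1 of the 4 values shown sits.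

As far as these compounds go, whether an amine, a carboxylic acid or a longer chain at this position would stay within the scatter of compound 3 and compound 4 remains open.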